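The compounds below may be only part of what the source reports. "The series", "measured", "known", "first", "only" and "open" are said of these compounds alone.

Among the measured compounds shown here, compound 2 `COC1Cc2c(csc2-c2ccc(C#N)cc2)C2(CCN(Cc3ccccc3)CC2)O1` gives the lower of the two numbers so far: in an assay on membranes from brain for displacement of a labelled ligand from Sigma non-opioid intracellular receptor 1 (Cavia porcellus), read by scintillation counting, with a stated time of 120 min (a higher number here means a weaker inhibitor, a lower number a stronger inhibitor), compound 2 gives 0.25 nM, while compound 1 `COc1ccc(-c2scc3c2CC(OC)OC32CCN(Cc3ccccc3)CC2)cc1` gives 2.2 nM in this assay, the step being an 8.8-fold lower number from compound 1 to compound 2 (0.94 log units; beyond the scatter). Compound 3 `COC1Cc2c(csc2-c2ccc(-c3ccccc3)cc2)C2(CCN(Cc3ccccc3)CC2)O1` differs from compound 2 by phenyl in place of cyano on an aromatic carbon. For the measured compounds named here, no measured step exchanges cyano for phenyl, and the one step known, cyano for methoxy, does not cover this change, so the expected step of a 4.0-fold higher number from compound 2 to compound 3 (0.60 log units; beyond the scatter) in this assay is set small and upward, with wide uncertainty. Compound 3 is therefore estimated at 1 nM, within 0.2 nM to 6 nM.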

Compound 3, inhibition constant: 30 nM
For compound 3 the middle estimate is 30-fold (1.48 log units) below the measured one; measured number outside the range, above it.
By their numbers in this assay, from the lowest: compound 2; then compound 1; then compound 3.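

In this assay, among the compounds shown here, this aromatic carbon, para to a large group, proves far more sensitive to its substituent than the first step showed: phenyl in place of cyano gives the largest step so far (a 120-fold higher number from compound 2 to compound 3 (2.08 log units; beyond the scatter)), and phenyl also compares poorly with methoxy (a 14-fold higher number from compound 1 to compound 3 (1.13 log units; beyond the scatter)). Of the three groups shown here, phenyl gives the highest number, so a second aromatic ring at this place is not tolerated as cyano and methoxy are.

As far as these compounds go, whether an amine, a carboxylic acid or a saturated cyclohexyl ring at this carbon would fall nearer cyano or phenyl stays open. Nothing available explains why the number rises.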